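From Urea to Amide on a Shared Pyrazole-Free Core

The compounds below may be only part of what the source reports. "The series", "measured", "known", "first", "only" and "open" are said of these compounds alone.

Measured so far, in a functional assay on CAKI-1 cells (Homo sapiens) for inhibition, read by sulforhodamine B assay, with a stated time of 48 h, tested at 10 uM; on this read-out lower numbers stand for a stronger effect and higher numbers for a weaker effect at the one concentration tested:
compound 1 `COc1cc(Cl)cc(-c2nn(-c3cccc(NC(=O)Nc4ccc(Cl)c(Cl)c4)c3)cc2-c2ccncc2)c1` gives 7.49%
compound 2 `COc1cc(Cl)cc(-c2nn(-c3cccc(NC(=O)Nc4cccc(C(F)(F)F)c4)c3)cc2-c2ccncc2)c1` gives 16.1%

Compound 2 has the higher of the two numbers, but only by a number 8.6 percentage points higher from compound 1 to compound 2 (within the scatter), so on this assay compound 2 and compound 1 cannot be told apart. Compound 3 `COc1cc(Cl)cc(-c2nn(-c3cccc(NC(=O)c4cccc(C(F)(F)F)c4)c3)cc2-c2ccncc2)c1` differs from compound 2 by 3-(trifluoromethyl)phenyl in place of (3-(trifluoromethyl)phenyl)amino on a carbonyl carbon. For the measured compounds named here, the one measured step swapped one aromatic ring for another and left the carbonyl-bearing link untouched, so no measured step bears on this change. Compound 3 is therefore expected to move by a number 5.9 percentage points higher from compound 2 to compound 3 (within the scatter) with little confidence in direction. Compound 3 is estimated at 22%, within 8% to 45%.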

Compound 3, a percentage reported as activity, at one concentration (the size of the read-out at that concentration, not a potency): 54%
For compound 3 the middle estimate is 32 percentage points below the measured one; measured number outside the range, above it.
By their numbers in this assay, from the lowest: compounds 1 and 2 (each within the scatter of the next); then compound 3.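

In this assay the link at the carbonyl carbon proves far more sensitive than the aromatic ring swap seen earlier: removing the amino nitrogen gives a number 37.9 percentage points higher from compound 2 to compound 3 (beyond the scatter) and so a clearly weaker effect at the one concentration tested. The step of a number 46.5 percentage points higher from compound 1 to compound 3 (beyond the scatter) points the same way, although it changes the ring as well. Nothing measured here explains this loss.

Still open, as far as these compounds go, is whether a methylene group in place of the amino nitrogen would retain the effect. A methyl group on that nitrogen would test whether the nitrogen itself or its hydrogen matters.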